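The source may hold more compounds than are shown below. What is called first, only, known or untested is meant among the compounds shown, and "the series" means these compounds.

Measured compounds:
- compound 1 `CC(=O)NC1CCN(c2ncnc3[nH]cc(-c4cccc(Cl)c4)c23)CC1` — in an assay for inhibition of serine/threonine-protein kinase 3 (Homo sapiens), read by luminescence and ADP-Glo, in the presence of a further agent that is not named here (on this read-out higher numbers stand for weaker inhibition and lower numbers for stronger inhibition), compound 1 gives 36 nM
- compound 2 `OC1CCN(c2ncnc3[nH]cc(-c4cccc(Cl)c4)c23)CC1` — in this assay compound 2 gives 127 nM

Compound 2 stands highest of the two numbers in this assay; its nearest neighbour is compound 1, reached by a 3.5-fold higher number from compound 1 to compound 2 (0.55 log units; beyond the scatter). For the measured compounds named here, that single step, hydroxy in place of acetamido on a saturated ring carbon of the shared core, is the only measured step, and it shows the hydroxy analogue as the weaker of the pair.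

Compound 3 `CNC1CCN(c2ncnc3[nH]cc(-c4cccc(Cl)c4)c23)CC1` is not yet measured in this assay. It differs from compound 2 by methylamino in place of hydroxy on a saturated ring carbon, read one bond further out as 4-hydroxypiperidin-1-yl to 4-(methylamino)piperidin-1-yl. Going by the values given here, no measured step replaces hydroxy by methylamino at this position, so the only bearing comes from compound 2 itself and from the observation that the acetamido analogue, compound 1, sits below it by a 3.5-fold higher number from compound 1 to compound 2 (0.55 log units; beyond the scatter). On that basis compound 3 is expected to give 60 nM, within 15 nM to 250 nM. The step this estimate implies, a 2.1-fold lower number from compound 2 to compound 3 (0.33 log units; beyond the scatter), is expected to be small, at the edge of the scatter, tending toward a lower number.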

Compound 3, half-maximal inhibitory concentration: 293 nM
For compound 3 the middle estimate is 4.9-fold (0.69 log units) below the measured one; measured number outside the range, above it.
By their numbers in this assay, from the lowest: compound 1; then compound 2; then compound 3.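

In this assay, the swap of hydroxy for methylamino on this saturated ring carbon gives a 2.3-fold higher number from compound 2 to compound 3 (0.36 log units; beyond the scatter), so the position does respond to this change, and in the direction opposite to the step from compound 1 to compound 2. Keeping a nitrogen on the ring carbon and changing only what it carries, methyl in place of acetyl, gives an 8.1-fold higher number from compound 1 to compound 3 (0.91 log units; beyond the scatter), the largest step in the series; a nitrogen at this place therefore does not by itself go with the low number of compound 1, and the acetyl group on it matters, while hydroxy falls between the two amine-derived groups. The data hold no measurement that explains this order.

Still open, as far as these compounds go, is whether the low number of compound 1 is particular to acetyl or carries over to a propanoyl or methanesulfonyl group on the same nitrogen. Also open, from the compounds shown here alone, is where the unsubstituted amine, dimethylamino or methoxy would fall relative to methylamino and hydroxy, and whether this order holds with any other substituent on the shared core.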